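A few compounds are considered here, and "the series" means these few. Any claim that something is new, unique, unknown or untested is made for them only; others in the source may bear on it.

Of the compounds shown here, three share one core and have been tested in a functional assay on the whole organism (artery, strain albino) with Rattus norvegicus as the target, with a stated time of 900 min, at a dose of 10 mg/kg by the oral route; on this read-out lower numbers stand for less inhibition and higher numbers for more inhibition at the one dose given (going by the name of the read-out). Compound 1, `CC1=C(C(=O)Nc2ccc(F)cc2)C(c2ccc([N+](=O)[O-])cc2)N=C(SCc2ccccc2)N1`, gives 21%. Compound 2, `CC1=C(C(=O)Nc2ccc(F)cc2)C(c2ccc([N+](=O)[O-])cc2)N=C(SCc2ccc(F)cc2)N1`, differs from compound 1 only by a fluoro in place of hydrogen on an aromatic carbon of the benzyl group, and in this assay compound 2 gives 13.8%; the step of a number 7.2 percentage points lower from compound 1 to compound 2 (within the scatter) stays within the usual scatter. Compound 3, `CC1=C(C(=O)Nc2ccc(Br)cc2)C(c2ccc(Cl)cc2Cl)N=C(SCc2ccccc2)N1`, differs from both in several places, and in this assay compound 3 gives 8.2%. That is the lowest of the three numbers, but the gap to compound 2 lies within the scatter and only the gap to compound 1 lies beyond it.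

Compound 4, `CC1=C(C(=O)Nc2ccc(Br)cc2)C(c2ccc(Cl)cc2Cl)N=C(SCc2cccc(Cl)c2)N1`, has not yet been measured. Compared with compound 3 it carries chloro in place of hydrogen on an aromatic carbon, so that benzylsulfanyl becomes (3-chlorobenzyl)sulfanyl. Among the compounds with values here, the one measured step that resembles this, a halogen entering the same benzyl ring, is a number 7.2 percentage points lower from compound 1 to compound 2 (within the scatter), a change within the scatter. On that basis the step is expected to be a number 0.2 percentage points lower from compound 3 to compound 4 (within the scatter), nothing beyond the scatter in either direction. Compound 4 is therefore estimated at 8%, with a range from 0% to 20%.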

Compound 4, a percentage reported as inhibition, in the whole organism at one dose (the size of the read-out at that dose, not a potency): 7.2%
Estimate against measurement, compound 4: 0.8 percentage points above; the measured number falls inside the stated range.
By their numbers in this assay, from the lowest: compounds 4, 3, 2 and 1 (each within the scatter of the next, the first and the last beyond it).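

In this assay chloro in place of hydrogen, turning benzylsulfanyl into (3-chlorobenzyl)sulfanyl, gives a number 1 percentage points lower from compound 3 to compound 4 (within the scatter) and so shows no change that this read-out can separate from ordinary variation. The fluoro step, a number 7.2 percentage points lower from compound 1 to compound 2 (within the scatter) on a parent with different groups elsewhere, also stays within the scatter, so in both available pairs, with two different halogens, a halogen entering the benzyl ring produces no clear change. No independent measurement is available to explain this result.

From the compounds shown here alone, with only these two pairs, it remains open whether chloro at this place would behave the same way on compound 1, whose number leaves more room for a fall than that of compound 3, or whether other places on the ring would respond differently. Going by these compounds, it is also open whether a group of a different kind on this benzyl ring, such as an amine or a carboxylic acid, or a longer chain in place of benzyl, would move the number beyond the scatter in either direction.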